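The source may hold more compounds than are shown below. What is called first, only, known or untested is meant among the compounds shown, and "the series" means these compounds.

Measured compounds:
- compound 1, `COC(=O)C[S+]([O-])CC1CN(C)CCC1c1ccc(Cl)cc1`, 53 nM in an assay on isolated protein for inhibition of Norepinephrine transporter (Rattus norvegicus), read by radioligand binding; a lower number here means a stronger inhibitor, a higher number a weaker inhibitor
- compound 2, `CN1CCC(c2ccc(Cl)cc2)C(C[S+]([O-])CCO)C1`, 42 nM
- compound 3, `COCCSCC1CN(C)CCC1c1ccc(Cl)cc1`, 6 nM

Compound 3 holds the lowest number of the three; the nearest is compound 2, with a 7.0-fold lower number from compound 2 to compound 3 (0.85 log units; beyond the scatter), and the furthest compound 1, with an 8.8-fold lower number from compound 1 to compound 3 (0.95 log units; beyond the scatter). Compound 4, `COCC[S+]([O-])CC1CN(C)CCC1c1ccc(Cl)cc1`, differs from compound 3 by a group of 6 heavy atoms (3 carbon, 2 oxygen, 1 sulfur; no ring) in place of a group of 5 heavy atoms (3 carbon, 1 oxygen, 1 sulfur; no ring), on a saturated chain carbon bound to a saturated ring carbon. The steps from compound 1 and compound 2 to compound 3 bear on this change, since each of them replaced an oxygen-richer group on that chain carbon with the (2-methoxyethyl)sulfanyl group and gave a modest drop in the number. Compound 4 moves back toward such a group, so a modest rise in this assay is expected, of about a 6.7-fold higher number from compound 3 to compound 4 (0.82 log units; beyond the scatter). For compound 4 the estimate is 40 nM, with a range from 15 nM to 110 nM.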

Compound 4, inhibition constant: 25 nM
The estimate for compound 4 lay 1.6-fold (0.20 log units) above the measured number; the measured number falls inside the stated range.
By their numbers in this assay, from the lowest: compound 3; then compounds 4, 2 and 1 (each within the scatter of the next, the first and the last beyond it).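

Going by these compounds alone, the group entering on the saturated chain carbon bound to a saturated ring carbon holds one oxygen more than (2-methoxyethyl)sulfanyl and gives a 4.2-fold higher number from compound 3 to compound 4 (0.62 log units; beyond the scatter) in this assay, which separates this change from the chain-end changes that the earlier steps carried with it. At the chain end, methyl in place of hydrogen gives a 1.7-fold lower number from compound 2 to compound 4 (0.23 log units; within the scatter), while methoxymethyl in place of methoxycarbonyl gives a 2.1-fold lower number from compound 1 to compound 4 (0.33 log units; beyond the scatter). Nothing given here explains these steps. As far as these compounds go, how an amine, a carboxylic acid or a longer chain at the chain end would read in this assay remains open.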